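Chloro on the Pendant Phenyl: Rat Half-Life Expectation

The source may report more compounds than this note shows. Statements on the series, on what has been measured and on what is new or still open speak of the compounds shown alone.

Measured compounds:
- compound 1, `CS(=O)(=O)c1cc(Cl)c(NC(=O)N2CCN3C(=O)N([C@H]4C[C@@H]4c4ccccc4)C(=O)[C@@H]3C2)c(Cl)c1`: 3.2 h
- compound 2, `O=C(Nc1cccnc1-c1ccccc1)N1CCN2C(=O)N([C@H]3C[C@@H]3c3ccccc3)C(=O)[C@@H]2C1`: 4.9 h

Both compounds were examined in an ADME assay on the whole organism for metabolic stability, with Rattus norvegicus as the target; on this read-out higher numbers stand for a longer-lived compound and lower numbers for a shorter-lived compound. Compound 1 gives 3.2 h in this assay. In compound 2 a phenyl on the pyridine stands in place of the chlorinated methylsulfonylphenyl of compound 1. Compound 2 gives 4.9 h; it has the higher of the two numbers, but its gap to compound 1 lies within the usual scatter of such measurements, so the two are not distinguished by this read-out.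

The step of interest leads from compound 2 to compound 3, `O=C(Nc1cccnc1-c1cccc(Cl)c1)N1CCN2C(=O)N([C@H]3C[C@@H]3c3ccccc3)C(=O)[C@@H]2C1`, which has not yet been measured in this assay. The two structures differ in one place: chloro in place of hydrogen on an aromatic carbon. Among the measured compounds shown here, no measured pair in this set shows what such a change does to the half-life in the rat, and the two values at hand do not separate from each other. The expectation for compound 3 is therefore a step from compound 2 that stays within the scatter in either direction, a 1.1-fold higher number from compound 2 to compound 3 (0.05 log units; within the scatter). Compound 3 is expected to give about 5.5 h, with a plausible range from 2.5 h to 12 h.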

Compound 3, half-life: 1.3 h
The estimate for compound 3 lay 4.2-fold (0.63 log units) above the measured number; the measured number lies below the stated range.
By their numbers in this assay, from the lowest: compound 3; then compounds 1 and 2 (each within the scatter of the next).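

Chloro in place of hydrogen on an aromatic carbon of the six-membered carbon ring, the change from phenyl to 3-chlorophenyl, gives in this assay a 3.8-fold lower number from compound 2 to compound 3 (0.58 log units; beyond the scatter) and is the only step here that lies beyond the scatter. The half-life of this series in the rat therefore responds to a single added chlorine at this position, which compounds 1 and 2 could not show, since their two numbers do not separate from each other and they share no such single-atom change. The compounds shown contain no measurement that accounts for this shorter half-life.

As far as these compounds go, it remains open whether the shorter half-life belongs to chlorine itself or to any group at this carbon, which a fluoro, methyl, methoxy or nitrile group in the same place would begin to answer. From the compounds shown here alone, it also remains open whether chloro on another carbon of this ring would give the same step, and whether the same change would act alike on a ring carrying other groups, such as the methylsulfonyl group of compound 1.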